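Replacing one aryl group on a sulfonamide nitrogen

This account rests on a few compounds, and the source may have more. Where it says the series, first, only, none or still open, it means among the compounds named here.

In a functional assay on K562 cells (Homo sapiens) for cytotoxicity, read by trypan blue exclusion, with a stated time of 96 h (a lower number here means a stronger inhibitor, a higher number a weaker inhibitor), compound 1 (`COc1cc(OC)c(/C=C/S(=O)(=O)Nc2ccc(F)c(N)c2)c(OC)c1`) gives 5000 nM and cannot be told apart from compound 3 (`COc1ccc(/C=C/S(=O)(=O)Nc2ccc(F)cc2)cc1`) at 10000 nM since the two lie within the usual scatter. Among the measured compounds shown here, compound 2 (`O=S(=O)(/C=C/c1ccccc1)Nc1ccc(Cl)cc1`) gives 20000 nM and that number is higher than the one for compound 1 by more than the scatter. Compound 1 therefore stands at the stronger end of this small set, level with compound 3.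

Compound 4 (`COc1cc(OC)c(/C=C/S(=O)(=O)Nc2ccc(OC)c(F)c2)c(OC)c1`) keeps the core of compound 1 and carries 3-fluoro-4-methoxyphenyl in place of 3-amino-4-fluorophenyl on a sulfonamide nitrogen. For the measured compounds named here, no measured pair here shows a single change of this kind, so the data give no direct guide to its size. The closest measured relative is compound 1 at 5000 nM and the estimate starts from there. A modest gain in strength is expected, with an estimated change of a 3.3-fold lower number from compound 1 to compound 4 (0.52 log units; beyond the scatter) in this assay and wide uncertainty around it. For compound 4 the expected value is 1500 nM with an estimated range from 100 nM to 10000 nM in this measurement.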

Compound 4, half-maximal inhibitory concentration: 75 nM
Compound 4: middle estimate off by 20-fold (1.30 log units), on the high side, outside the stated range (below it).
By their numbers in this assay, from the lowest: compound 4; then compounds 1, 3 and 2 (each within the scatter of the next, the first and the last beyond it).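

On the sulfonamide nitrogen, the aryl group has a strong influence on the result: with the core of compound 1 kept, 3-fluoro-4-methoxyphenyl in place of 3-amino-4-fluorophenyl gives a 67-fold lower number from compound 1 to compound 4 (1.82 log units; beyond the scatter) in this assay. The earlier compounds shown here differed from one another in more than one place, so they could not show that a change at this single position can produce a step of this size. The swap removes an amino group with its hydrogen-bond donor, adds a methoxy group and shifts the fluorine, and nothing measured here explains the gain.

Which of these three changes matters most stays open: they arrive together in one swap. It is also unknown whether an ethoxy or hydroxyl group in place of the methoxy would keep this strength.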